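Butyl in place of methoxy on an oxadiazole-linked indole

A few compounds are considered here, and "the series" means these few. Any claim that something is new, unique, unknown or untested is made for them only; others in the source may bear on it.

Compound 1 `COc1cc(/C(N)=N/OC(=O)Cc2c[nH]c3ccccc23)cc(OC)c1OC` gives 19500 nM in a functional assay on cells (Splenocyte, Mus musculus, strain BALB/c) for inhibition, read by scintillation counting and thymidine incorporation, with stated times of 48 h and 8 h; a lower number here means a stronger inhibitor, a higher number a weaker inhibitor.
Compound 2 `COc1ccc(-c2nc(Cc3c[nH]c4ccccc34)no2)cc1` gives > 50000 nM in this assay.
Compound 3 `COc1ccc(-c2nc(Cc3c[nH]c4ccccc34)no2)c(OC)c1` gives 8600 nM in this assay.

Compound 2 stands apart from the other two: its result is only a limit of the assay, not a number, as the limit of > 50000 nM in this assay, at which 1 of the 3 values shown sits, records. Compound 1 and compound 3 each have a measured value, and the latter is the lower of the two.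

Within the data shown here, the one measured step that touches the ring in question is an at least 5.8-fold lower number from compound 2 to compound 3 (0.76 log units; beyond the scatter). Compound 4 `CCCCc1ccc(-c2nc(Cc3c[nH]c4ccccc34)no2)cc1` differs from compound 2 at the same kind of position, (butyl in place of methoxy on an aromatic carbon). Among the measured compounds shown here, no measured pair shows a butyl entering or a methoxy leaving, so that step gives only indirect guidance, and the starting point itself is a limit.

Compound 4 is therefore expected to land near that limit or somewhat below it, an estimated at least 1.6-fold lower number from compound 2 to compound 4 (0.22 log units; that floor lies within the scatter). The estimate for compound 4 is 30000 nM, with a range from 7000 nM to 100000 nM.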

Compound 4, half-maximal inhibitory concentration: 11200 nM
Beside the measured number, compound 4's estimate is 2.7-fold (0.43 log units) above it, and the stated range covers the measured number.
By their numbers in this assay, from the lowest: compounds 3, 4 and 1 (each within the scatter of the next, the first and the last beyond it). At a limit, above all of these: compound 2.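

Exchanging the methoxy for butyl on this aromatic carbon, para to a large group, gives an at least 4.4-fold lower number from compound 2 to compound 4 (0.64 log units; beyond the scatter) in this assay. The earlier compounds shown here showed compound 2 moving off its limit only when a further methoxy was added to the ring, whereas this change replaces the existing methoxy, so a measurable value at this position does not depend on that group or on a hydrogen-bond acceptor within it. On these data alone, the true size of the step remains unknown because the result for compound 2 is a limit and not a number: the limit of > 50000 nM in this assay, at which 1 of the 4 values shown sits.

The compounds shown include no ethyl, no longer chain and no amine on this carbon, so it remains open whether chain length matters here. Nor do they show whether butyl combined with the added methoxy of compound 3 would lower the number further.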